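The source may hold more compounds than are shown below. What is called first, only, known or untested is meant among the compounds shown, and "the series" means these compounds.

Of the compounds shown here, two have so far been measured in an assay for inhibition of Pro-cathepsin H (Homo sapiens), read by fluorescence, tested at 50 uM; a lower number here means less inhibition, a higher number more inhibition at the concentration tested (going by the name of the read-out). Compound 1 `Cc1ccc(-c2nc(S)[nH]c(=O)n2)cc1` gives 6.58%. Compound 2 `O=c1nc(SCc2ccccc2)nc(SCc2cccc(F)c2)[nH]1` gives 4.18% in this assay, a number close to that of compound 1; the difference between them lies within the usual scatter of repeated measurements, so neither can be placed above the other. Both numbers are small, meaning little inhibition at the concentration tested.

Compound 3 `O=c1nc(SCc2ccccc2)nc(SCc2ccc(Cl)cc2)[nH]1` has not yet been measured. It differs from compound 2 in one place: 4-chlorophenyl in place of 3-fluorophenyl on a saturated chain carbon bound to a sulfur. Within the data shown here, no step between two measured compounds shows what such a swap does in this assay, so there is no measured guide for it. With both measured compounds showing small inhibition, the step of a number 0.8 percentage points higher from compound 2 to compound 3 (within the scatter) is expected to stay within the scatter, in no particular direction. Compound 3 is therefore estimated at 5%, with a range from -5% to 15%.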

Compound 3, a percentage reported as inhibition, at one concentration (the size of the read-out at that concentration, not a potency): 6.91%
Beside the measured number, compound 3's estimate is 1.9 percentage points below it; measured number inside the range.
By their numbers in this assay, from the lowest: compounds 2, 1 and 3 (each within the scatter of the next).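

Among these compounds, this is the first step that changes a single place in this assay: 4-chlorophenyl in place of 3-fluorophenyl on a saturated chain carbon bound to a sulfur gives a number 2.7 percentage points higher from compound 2 to compound 3 (within the scatter) and so cannot be told apart from no change. Because the swap alters both the halogen and the name of its ring position at once, this single step cannot assign any share of it to either one. No separate measurement bears on this result.

Going by these compounds, it remains open whether a carboxylic acid or an amine on this phenyl ring, or a longer chain in place of the benzyl group, would move the number beyond the scatter. On these data alone, it also remains open whether fluorine and chlorine would read alike at the same ring position.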